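The compounds below may be only part of what the source reports. "The series", "measured", "known", "first", "only" and "open" are said of these compounds alone.

Measured compounds:
- compound 1 `c1ccc(-c2ccsc2)c(OCC2=NCCN2)c1`: 98%
- compound 2 `Cc1ccc(-c2ccccc2OCC2=NCCN2)s1`: 97%

In a functional assay with Alpha-1A adrenergic receptor (Homo sapiens) as the target, read by calcium flux (on this read-out higher numbers stand for larger maximal responses and lower numbers for smaller maximal responses), compound 1 gives 98% and compound 2 gives 97%. On these two numbers compound 2 stands lowest, with compound 1 nearest; the step is a number 1 percentage points lower from compound 1 to compound 2 (within the scatter), so the two values are not distinguishable.

Compound 3 `Cc1cc(-c2ccccc2OCC2=NCCN2)sn1` is the next member, not yet measured in this assay. Its change from compound 2: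
3-methyl-1,2-thiazol-5-yl in place of 5-methylthiophen-2-yl on an aromatic carbon

Among the measured compounds shown here, the one measured step that bears on this place is the exchange of the five-membered aromatic ring on the same aromatic carbon, from compound 1 to compound 2, which gave a number 1 percentage points lower from compound 1 to compound 2 (within the scatter). For the measured compounds named here, that step replaced one ring with a single hetero atom by another such ring; the present change brings in a ring with two hetero atoms and a second hydrogen-bond acceptor, for which no measured step exists. Going by the values given here, on the one relevant step, no change beyond the scatter is expected in this assay for compound 3, with a somewhat wider range to allow for the second hetero atom; the expected step is a number 3 percentage points lower from compound 2 to compound 3 (within the scatter). Compound 3 is therefore estimated at 94%, between 78% and 104%.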

Compound 3, largest response reached (reported as maximum), in percent of the reference or control that the assay uses: 75%
Beside the measured number, compound 3's estimate is 19 percentage points above it, and the stated range ends above it.
By their numbers in this assay, from the lowest: compound 3; then compounds 2 and 1 (each within the scatter of the next).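

In this assay, among the compounds shown here, this aromatic carbon proves sensitive to the identity of the five-membered ring: 3-methyl-1,2-thiazol-5-yl in place of 5-methylthiophen-2-yl gives a number 22 percentage points lower from compound 2 to compound 3 (beyond the scatter) and, in place of thiophen-3-yl, gives a number 23 percentage points lower from compound 1 to compound 3 (beyond the scatter) whereas the only earlier exchange at this place gave a number 1 percentage points lower from compound 1 to compound 2 (within the scatter) and so showed no sensitivity. The change from compound 2 to compound 3 keeps the methyl substituent and the count of 6 heavy atoms in the group, and what differs under the computed comparison is a ring with 2 hetero atoms and 2 hydrogen-bond acceptors in place of a ring with 1 of each. The data at hand offer no measurement that accounts for this lower maximal response.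

Still open, going by these compounds, is whether the lower response goes with the ring nitrogen as such or with its place in the ring, a question that a 1,3-thiazol-5-yl or a 1,2-oxazol-5-yl group on the same carbon would address. Also open, on these data alone, is what the methyl group contributes on the 1,2-thiazole ring, and how a six-membered pyridin-3-yl group would behave at this place.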